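Swapping an alkyne tail for an ester tail on compound 3

This account rests on a few compounds, and the source may have more. Where it says the series, first, only, none or still open, it means among the compounds named here.

Compound 3 `C#CC(C)OC(=O)c1ccc(C(CC)(CC)c2ccc(OCC(=O)C(C)(C)C)c(C)c2)n1CC` has the highest number of the three measured compounds in an assay on HL-60 cells for agonist activity at vitamin D3 receptor (Homo sapiens), read by microscopy, with a stated time of 96 h; a higher number here means that more compound is needed for the effect, a lower number that less compound is needed. Compound 3 gives 210 nM, while compound 1 `CCN(CC)CCNC(=O)c1ccc(C(CC)(CC)c2ccc(OCC(=O)C(C)(C)C)c(C)c2)n1CC` gives 91 nM and compound 2 `CCn1c(C(=O)NCCN)ccc1C(CC)(CC)c1ccc(OCC(=O)C(C)(C)C)c(C)c1` gives 120 nM. The step of a 2.3-fold higher number from compound 1 to compound 3 (0.36 log units; beyond the scatter) is modest, and a 1.8-fold higher number from compound 2 to compound 3 (0.24 log units; within the scatter) lies within the scatter. Compound 4 `CCOC(=O)CC(C)OC(=O)c1ccc(C(CC)(CC)c2ccc(OCC(=O)C(C)(C)C)c(C)c2)n1CC` differs from compound 3 by (ethoxycarbonyl)methyl in place of ethynyl on a saturated chain carbon bound to an oxygen next to a carbonyl group and a saturated chain carbon. Going by the values given here, no measured step alters this position of the ester side chain; the closest comparison is a 1.3-fold higher number from compound 1 to compound 2 (0.12 log units; within the scatter), where a change at the far end of a side chain made no difference beyond the scatter. A step no larger than the scatter is therefore expected for compound 4, roughly a 1.2-fold higher number from compound 3 to compound 4 (0.08 log units; within the scatter). Compound 4 is estimated at 250 nM, with a range from 100 nM to 650 nM.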

Compound 4, half-maximal effective concentration: > 50000 nM
Compound 4 gave a limit, no number; the forecaster's own chance of this, stated with the estimate: 5%; at least 200-fold (2.30 log units) between middle value and limit.
By their numbers in this assay, from the lowest: compounds 1, 2 and 3 (each within the scatter of the next, the first and the last beyond it). At a limit, above all of these: compound 4.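

In this assay compound 4 gives > 50000 nM, which is a limit and not a number. Going by these compounds alone, this position of the ester side chain tolerates far less change than the earlier compounds suggested: replacing ethynyl with (ethoxycarbonyl)methyl gives an at least 230-fold higher number from compound 3 to compound 4 (2.37 log units; beyond the scatter). The compounds with amide side chains also lie far from compound 4, with an at least 410-fold higher number from compound 2 to compound 4 (2.61 log units; beyond the scatter) and an at least 540-fold higher number from compound 1 to compound 4 (2.73 log units; beyond the scatter).

With only ethynyl and (ethoxycarbonyl)methyl shown here, it remains open whether the length of the group or the ester within it drives the loss. A plain propyl chain or a carboxylic acid in this place would help separate the two.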